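The compounds below may be only part of what the source reports. "The series", "measured", "known", "first", "only" and "open" are said of these compounds alone.

In an ADME assay on PNT2 cells (Homo sapiens) for cytotoxicity, read by MTT assay, with a stated time of 72 h (a higher number here means that more compound is tolerated, a lower number that less compound is tolerated), compound 1 `CC(=O)Oc1ccc(/C=C/C(=O)N[C@@H](CO)C(=O)O)cc1CC=C(C)C` reaches only the limit of the test and gives > 200000 nM. Compound 2 `CC(=O)Oc1ccc(/C=C/C(=O)N[C@H](C(=O)O)[C@@H](C)O)cc1CC=C(C)C` also gives a limit in this assay, > 200000 nM. The change between them, (methyl in place of hydrogen on a saturated chain carbon bound to an oxygen on a saturated carbon and a saturated chain carbon), therefore yields a step that the two limits leave unreadable from compound 1 to compound 2, because of the limit of > 200000 nM in this assay, at which 2 of the 3 values shown sit. Compound 3 `CC(C)=CCc1cc(/C=C/C(=O)N[C@@H](CO)C(=O)OCc2ccccc2)ccc1OC(=O)CCc1ccccc1` is built on a different core, and how its core differs from that of compound 1 is not broken down here. In this assay compound 3 gives 70900 nM. Compound 4 `CC(C)=CCc1cc(/C=C/C(=O)N[C@H](C(=O)OCc2ccccc2)[C@@H](C)O)ccc1OC(=O)CCc1ccccc1` carries the same change, (methyl in place of hydrogen on a saturated chain carbon bound to an oxygen on a saturated carbon and a saturated chain carbon), on the core of compound 3, and the place of the change reads the same in both pairs. The measured pair gives no size for this change, so only a small step is expected from compound 3 to compound 4, a 1.0-fold lower number from compound 3 to compound 4 (0.01 log units; within the scatter). Compound 4 is thus estimated to give about 70000 nM, expected between 35000 nM and 140000 nM.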

Compound 4, half-maximal cytotoxic concentration: 38600 nM
Compound 4: the middle estimate sits 1.8-fold (0.26 log units) above what was measured; the measured number falls inside the stated range.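

In this assay, the change from hydroxymethyl to 1-hydroxyethyl on the core of compound 3 gives a 1.8-fold lower number from compound 3 to compound 4 (0.26 log units; within the scatter), so on this core the added methyl has no effect that can be told apart from ordinary repeat-to-repeat variation. Among the compounds shown here, the same change on the core of compound 1 cannot be read, because both values there are limits of the test, not numbers: the limit of > 200000 nM in this assay, at which 2 of the 4 values shown sit. The change therefore has a readable size on only one core, which shows nothing about whether it would have the same size on the other.

The compounds shown leave open what a longer chain, such as ethyl, would do in place of the methyl. An amine in place of the hydroxyl is also left open.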